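Cytotoxicity on HEp-2 cells: tert-butyl to cyclopropylmethyl

The source may hold more compounds than are shown below. What is called first, only, known or untested is meant among the compounds shown, and "the series" means these compounds.

The series shares one core, seen in compound 1 `N#CCCCn1c(Cn2c(=O)[nH]c3ccncc32)nc2ccccc21`, compound 2 `CC(C)(C)n1c(=O)n(Cc2nc3ccccc3n2CCCC#N)c2cnccc21`, compound 3 `N#CCCCn1c(Cn2c(=O)n(C3CC3)c3ccncc32)nc2ccccc21` and the still unmeasured compound 4 `N#CCCCn1c(Cn2c(=O)n(CC3CC3)c3ccncc32)nc2ccccc21`. In an ADME assay on HEp-2 cells (Homo sapiens) for cytotoxicity (a lower number here means that less compound is tolerated, a higher number that more compound is tolerated), compound 1 gives 264000 nM. For compound 2 in this assay only a limit is recorded, > 86800 nM. Compound 3 in this assay gives > 151000 nM; 109000 nM (2 entries) across its entries. Among the compounds with values here, the only single-point change already measured, a step that the limit leaves unreadable from compound 1 to compound 2, cannot be sized, since one end is a limit; what can be said rests on the several entries of compound 3 in this assay, > 151000 nM; 109000 nM (2 entries) and on (the limit of > 86800 nM in this assay, at which 1 of the 3 values shown sits), both of which sit at the tolerant end of the range. The change now followed is cyclopropylmethyl in place of tert-butyl on an aromatic nitrogen. With every measured value of this core at or beyond the tolerant end, compound 4 is expected to stay there too, so the estimated step that the limit leaves unreadable from compound 2 to compound 4 is nothing beyond the scatter. For compound 4 in this assay the estimate is 150000 nM, between 60000 nM and 400000 nM.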

Compound 4, half-maximal cytotoxic concentration: 96500 nM
For compound 4 the middle estimate is 1.6-fold (0.19 log units) above the measured one; measured number inside the range.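

In this assay, filling this aromatic nitrogen now has a readable size: cyclopropylmethyl in place of hydrogen gives a 2.7-fold lower number from compound 1 to compound 4 (0.44 log units; beyond the scatter). For compound 2 the record is a limit, so neither step that runs through it can be read, and the change from tert-butyl to cyclopropylmethyl has no size: the limit of > 86800 nM in this assay, at which 1 of the 4 values shown sits. Compound 3, which carries cyclopropyl on the same nitrogen, has one entry that is a limit and one that is a number: the several entries of compound 3 in this assay, > 151000 nM; 109000 nM (2 entries)

The compounds shown leave open where tert-butyl itself falls, as only a number for compound 2 could settle that. They also leave open whether this modest step would hold for an amine, a carboxylic acid or a longer chain on this aromatic nitrogen.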